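The compounds below may be only part of what the source reports. "The series", "measured", "known", "first", "only" and "open" are said of these compounds alone.

Measured in an in vivo functional assay on the whole organism (MDA-MB-435 cells, Homo sapiens) for antiproliferative activity; a higher number here means a weaker inhibitor, a lower number a stronger inhibitor:

- Compound 1 `CO[C@@H](C(=O)NC1CC[C@@H](OC(=O)c2ccccc2)CNC1=O)[C@H](O)[C@@H](O)[C@H](O)/C=C/C(C)(C)C` gives 370 nM
- Compound 2 `CCCCCc1ccc(C(=O)O[C@@H]2CCC(NC(=O)[C@H](OC)[C@H](O)[C@@H](O)[C@H](O)/C=C/C(C)(C)C)C(=O)NC2)cc1` gives 20 nM
- Compound 3 `CCCCCCCCCCCCCC(=O)O[C@H]1CCC(NC(=O)[C@H](OC)[C@H](O)[C@@H](O)[C@H](O)/C=C/C(C)(C)C)C(=O)N(C)C1` gives 10 nM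

Compound 2 lies within the usual scatter of compound 3 and far from compound 1, so it belongs to the low-number end of this small set. The next compound to be tested is compound 4 `CO[C@@H](C(=O)NC1CC[C@@H](OC(=O)Cc2cccnc2)CNC1=O)[C@H](O)[C@@H](O)[C@H](O)/C=C/C(C)(C)C`, which has (pyridin-3-yl)methyl in place of 4-pentylphenyl on a carbonyl carbon. Among the compounds with values here, no measured compound carries this new group, so the data do not show what it does directly. Within the data shown here, one measured step bears on the change, the pentyl in place of hydrogen on an aromatic carbon: a 19-fold lower number from compound 1 to compound 2 (1.27 log units; beyond the scatter). Compound 4 has no pentyl, so a large step back towards compound 1 is expected in this assay, to a higher number. The expected step is a 20-fold higher number from compound 2 to compound 4 (1.30 log units; beyond the scatter). For compound 4 the estimated value is 400 nM, with an expected range of 120 nM to 1500 nM.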

Compound 4, half-maximal inhibitory concentration: 5850 nM
Compound 4: middle estimate off by 15-fold (1.17 log units), on the low side; measured number above the stated range.
By their numbers in this assay, from the lowest: compounds 3 and 2 (each within the scatter of the next); then compound 1; then compound 4.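

In this assay the group on the carbonyl carbon matters beyond the pentyl alone: there is a 290-fold higher number from compound 2 to compound 4 (2.47 log units; beyond the scatter) with (pyridin-3-yl)methyl in place of 4-pentylphenyl, and a 16-fold higher number from compound 1 to compound 4 (1.20 log units; beyond the scatter) with (pyridin-3-yl)methyl in place of phenyl. Losing the pentyl therefore does not account for the whole change, since compound 4 lies well past compound 1, which also has no pentyl, and so the (pyridin-3-yl)methyl group is worse here than plain phenyl. Nothing available explains why this group gives such a high number.

On these data alone, what remains open is which part of the new group carries the loss: a benzyl group or a plain pyridin-3-yl group on the same carbonyl carbon would separate the ring nitrogen from the extra methylene. As far as these compounds go, it also remains open whether a pentyl on the pyridine ring would recover the lost activity.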